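A few compounds are considered here, and "the series" means these few. Any claim that something is new, unique, unknown or untested is made for them only; others in the source may bear on it.

Compound 1 `CNC(=O)/C(C)=C/c1ccc(NC(=O)Nc2ccc(Cl)c(C(F)(F)F)c2)cc1` and compound 2 `CNC(=O)CCc1ccc(NC(=O)Nc2ccc(Cl)c(C(F)(F)F)c2)cc1` share a core and were tested in a functional assay on HepG2 cells (Homo sapiens) for inhibition, read by MTT assay, with a stated time of 120 h; a lower number here means a stronger inhibitor, a higher number a weaker inhibitor. Compound 1 gives 44300 nM, while compound 2 gives 21000 nM, so there is a 2.1-fold lower number from compound 1 to compound 2 (0.32 log units; beyond the scatter); the two differ by 2-(methylcarbamoyl)prop-1-en-1-yl in place of 2-(methylcarbamoyl)ethyl on an aromatic carbon. Compound 3 `CC1CN(C(=O)CCc2ccc(NC(=O)Nc3ccc(Cl)c(C(F)(F)F)c3)cc2)CC(C)O1` is made from compound 2 by 2,6-dimethylmorpholin-4-yl in place of methylamino on a carbonyl carbon. In this assay compound 3 reaches only the limit > 50000 nM, which is a limit of the assay and not a number (the limit of > 50000 nM in this assay, at which 1 of the 3 values shown sits). That yields an at least 2.3-fold higher number from compound 2 to compound 3 (0.37 log units; beyond the scatter). Compound 4 `C/C(=C\c1ccc(NC(=O)Nc2ccc(Cl)c(C(F)(F)F)c2)cc1)C(=O)N1CC(C)OC(C)C1`, not yet measured, arises from compound 1 by the same kind of change, (2,6-dimethylmorpholin-4-yl in place of methylamino on a carbonyl carbon), the place differing in that the carbonyl carbon neighbours a double-bonded chain carbon rather than a saturated chain carbon. Resting on the step from compound 2 to compound 3, compound 4 is expected to show a 2.3-fold higher number from compound 1 to compound 4 (0.35 log units; beyond the scatter). Compound 4 is therefore estimated at 100000 nM, within 40000 nM to 300000 nM.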

Compound 4, half-maximal inhibitory concentration: > 50000 nM
Compound 4 was reported as a limit; the forecaster's own chance of this, stated with the estimate: 75%; the middle value is on the limit's open side.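

In this assay compound 4 reaches only > 50000 nM, which is a limit of the assay and not a number. On the core of compound 1, the change from methylamino to 2,6-dimethylmorpholin-4-yl gives an at least 1.1-fold higher number from compound 1 to compound 4 (0.05 log units; that floor lies within the scatter), and set beside the same change on the saturated chain it reads: the same change on two cores in this assay, an at least 2.3-fold higher number (0.37 log units; beyond the scatter) from compound 2 to compound 3 and an at least 1.1-fold higher number (0.05 log units; that floor lies within the scatter) from compound 1 to compound 4; the limit leaves it open whether they differ This does not show that the change carries over with the same size, or that it raises the number on the core of compound 1 beyond the scatter, since compound 3 and compound 4 both sit at one limit: the limit of > 50000 nM in this assay, at which 2 of the 4 values shown sit.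

The compounds shown leave open how an unsubstituted morpholine or a small amine such as dimethylamine would read on either core. They also leave open whether a carboxylic acid in place of the amide would give a value short of that limit.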